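This account rests on a few compounds, and the source may have more. Where it says the series, first, only, none or still open, it means among the compounds named here.

Compound 3 `Nc1cc(N)c2nc(-c3ccccc3)c(Sc3ccc(Cl)c(Cl)c3)nc2c1` gives 7590 nM in a functional assay on NCI-H522 cells (Homo sapiens) for inhibition, read by sulforhodamine B assay, with a stated time of 48 h (a higher number here means a weaker inhibitor of growth, a lower number a stronger inhibitor of growth), the lowest of the two numbers shown; compound 1 `Nc1cc(N)c2nc(-c3ccccc3)c(Oc3ccc(Cl)c(Cl)c3)nc2c1` gives 8320 nM, and the step of a 1.1-fold lower number from compound 1 to compound 3 (0.04 log units; within the scatter) lies within the scatter. Compound 2 `Nc1cc(N)c2nc(-c3ccccc3)c(NCc3ccc(F)cc3)nc2c1` gives only a limit of the assay, < 100000 nM. The steps a step that the limit leaves unreadable from compound 1 to compound 2 and a step that the limit leaves unreadable from compound 2 to compound 3 are therefore unreadable. Compound 4 `Nc1cc(N)c2nc(-c3ccccc3)c(Oc3ccc(F)cc3)nc2c1` differs from compound 3 by 4-fluorophenoxy in place of (3,4-dichlorophenyl)sulfanyl on an aromatic carbon. Of this change, only the swap of a sulfanyl link for an oxy link has a measured counterpart, a 1.1-fold lower number from compound 1 to compound 3 (0.04 log units; within the scatter), and no number tells how the swap of two chlorines for one fluorine behaves. Compound 4 is thus expected near 15000 nM, between 4000 nM and 60000 nM. The expected step is a 2.0-fold higher number from compound 3 to compound 4 (0.30 log units; within the scatter), little beyond the scatter.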

Compound 4, concentration for 50% growth inhibition: 64600 nM
Compound 4: the middle estimate sits 4.3-fold (0.63 log units) below what was measured; the measured number lies above the stated range.
By their numbers in this assay, from the lowest: compounds 3 and 1 (each within the scatter of the next); then compound 4.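

In this assay, the group carried on the link proves to matter at this position, as the earlier swap of link atom alone did not show: 4-fluorophenyl in place of 3,4-dichlorophenyl on the oxygen gives a 7.8-fold higher number from compound 1 to compound 4 (0.89 log units; beyond the scatter). Changing the link as well gives an 8.5-fold higher number from compound 3 to compound 4 (0.93 log units; beyond the scatter), so the change of ring substituents alone already gives a step of nearly this size. The step from compound 2 cannot be read, because compound 2 gives only a limit: the limit of < 100000 nM in this assay, at which 1 of the 4 values shown sits.

Still open, going by these compounds, is how a 4-chlorophenyl or plain phenyl group on the same oxygen would behave, and whether an amine link carrying 3,4-dichlorophenyl would match the oxygen and sulfur links.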